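A furan for a phenyl at the assay limit

A few compounds are considered here, and "the series" means these few. Any claim that something is new, unique, unknown or untested is made for them only; others in the source may bear on it.

In an ADME assay on L02 cells (Homo sapiens) for inhibition, read by CCK-8 assay, with a stated time of 48 h (on this read-out lower numbers stand for stronger inhibition of growth and higher numbers for weaker inhibition of growth), compound 1 (`Cc1ccccc1Nc1nc(NC2CC2)ncc1Cl`) gives > 100000 nM as a limit of the assay and not a number. For the measured compounds named here, compound 2 (`Cc1ccccc1Nc1nc(NCc2ccccc2)ncc1Cl`) gives > 100000 nM as a limit too, so it stands without a readable number, and the one further value shown is also a limit. The change to compound 3 (`Cc1ccccc1Nc1nc(NCc2ccco2)ncc1Cl`) is furan-2-yl in place of phenyl on a saturated chain carbon bound to a nitrogen on an aromatic ring, in words furan-2-yl in place of phenyl on a saturated chain carbon bound to a nitrogen on an aromatic ring. Going by the values given here, the only measured step that bears on it is a step that the two limits leave unreadable from compound 1 to compound 2, benzyl in place of cyclopropyl on a nitrogen on an aromatic ring. Both of its ends sit at the limit of > 100000 nM in this assay, at which 2 of the 2 values shown sit, and it offers no size to carry over. Because compound 2 sits at > 100000 nM as a limit, no step beyond the scatter and no direction can be expected in this assay with any confidence. The expected step is a number no higher from compound 2 to compound 3 (the limit leaves the size open) and a further limit is the likeliest report. Compound 3 is estimated at 100000 nM with an expected range from 40000 nM to 200000 nM in this measurement.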

Compound 3, concentration for 50% growth inhibition: > 100000 nM
Compound 3: no number, only a limit; the forecaster's own chance of this, stated with the estimate: 80%; the middle value sits exactly at the limit.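

No new step can be read among compound 1, compound 2 and compound 3 in this assay, since each gives only a limit of the assay and not a number: the limit of > 100000 nM in this assay, at which 3 of the 3 values shown sit. The compounds shown leave open how cyclopropyl, benzyl and (furan-2-yl)methyl rank against one another on this read-out.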